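This account rests on a few compounds, and the source may have more. Where it says the series, first, only, none or still open, it means among the compounds named here.

Among the three compounds measured in a functional assay on WM 266-4 cells (Homo sapiens) for antiproliferative activity, read by MTT assay, with a stated time of 24 h (on this read-out higher numbers stand for weaker inhibition of growth and lower numbers for stronger inhibition of growth), compound 3 `COc1ccc(C2=NN(C(=O)c3ccc(Cl)nc3)C(c3ccc(OCc4ccccc4)cc3)C2)cc1` gives the highest number, 10600 nM. Compound 2 `COc1ccc(C2=NN(C(=O)c3cncc(Br)c3)C(c3ccc(OCc4ccccc4)cc3)C2)cc1` gives 6240 nM, which lies within the scatter of compound 3, while compound 1 `COc1ccc(C2=NN(C(=O)c3cccnc3Cl)C(c3ccc(Br)cc3)C2)cc1` gives 3050 nM, a gap beyond the scatter. Compound 4 `COc1ccc(C2=NN(C(=O)c3cccnc3Cl)C(c3ccc(OCc4ccccc4)cc3)C2)cc1` differs from compound 3 in one place: 2-chloropyridin-3-yl in place of 6-chloropyridin-3-yl on a carbonyl carbon. Going by the values given here, one measured step bears on this, a shift of the halogen on the same pyridine ring, a 1.7-fold higher number from compound 2 to compound 3 (0.23 log units; within the scatter). Compound 1 also carries the entering group, though with a different second aryl group, and gives 3050 nM. A small step, likely toward a lower number, is expected. Compound 4 is estimated at 5500 nM, in a range from 2200 nM to 14000 nM. The expected step is a 1.9-fold lower number from compound 3 to compound 4 (0.28 log units; within the scatter).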

Compound 4, concentration for 50% growth inhibition: 9150 nM
Compound 4: the middle estimate sits 1.7-fold (0.22 log units) below what was measured; the range from low to high includes it.
By their numbers in this assay, from the lowest: compound 1; then compounds 2, 4 and 3 (each within the scatter of the next).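

Putting 2-chloropyridin-3-yl in place of 6-chloropyridin-3-yl on this carbonyl carbon leaves the result unresolved (a 1.2-fold lower number from compound 3 to compound 4 (0.06 log units; within the scatter)), and the comparison with 5-bromopyridin-3-yl is no clearer (a 1.5-fold higher number from compound 2 to compound 4 (0.17 log units; within the scatter)). With benzyloxy held fixed, these three halogenated pyridines cannot be told apart, whereas benzyloxy in place of bromo on an aromatic carbon gives a step that can be read (a 3.0-fold higher number from compound 1 to compound 4 (0.48 log units; beyond the scatter)). Nothing measured here explains either finding. Still open, going by these compounds, is whether an amine or a carboxylic acid on the pyridine ring would shift the number, and whether a pyridine ring without any halogen would do so.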